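Cytotoxicity of a Methylamino Analogue in Lymphoblast Cells

The source may report more compounds than this note shows. Statements on the series, on what has been measured and on what is new or still open speak of the compounds shown alone.

Compound 1, `CCCCCOc1nc(N)nc2c1ncn2/C=C1/CC1(CO)CO`, gives > 20000 nM in an ADME assay on CCRF-HSB-2 cells (Homo sapiens) for cytotoxicity, with a stated time of 7 days; on this read-out lower numbers stand for higher toxicity in this test and higher numbers for lower toxicity in this test; this value is a limit of the assay and not a number.
Compound 2, `CCCCCCCCSc1nc(N)nc2c1ncn2/C=C1/CC1(CO)CO`, gives 60000 nM in this assay.
Compound 3, `CCCCOc1nc(N)nc2c1ncn2/C=C1/CC1(CO)CO`, gives > 20000 nM in this assay; this value also is a limit of the assay.

Compound 1 therefore stands at the limit rather than at a measured point, and it shares that position with compound 3, as the limit of > 20000 nM in this assay, at which 2 of the 3 values shown sit, records. Compound 2 is the only one of the three with a number on this read-out, and all three sit at concentrations where little toxicity is seen.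

Compound 4, `CNc1nc(N)nc2c1ncn2/C=C1/CC1(CO)CO`, differs from compound 1 by methylamino in place of pentyloxy on an aromatic carbon. Going by the values given here, the steps that could inform this change are a step that the limit leaves unreadable from compound 1 to compound 2, a step that the two limits leave unreadable from compound 1 to compound 3 and a step that the limit leaves unreadable from compound 2 to compound 3; none of them yields a readable size, so no measured step transfers to the new change.

With the measured compounds all showing low toxicity, no step beyond the usual scatter is expected here, and the step from compound 1 to compound 4 is estimated as a step that the limit leaves unreadable from compound 1 to compound 4. Compound 4 is expected to give about 50000 nM, between 15000 nM and 200000 nM, in this assay.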

Compound 4, half-maximal cytotoxic concentration: > 20000 nM
Compound 4 gave a limit, no number; the forecaster's own chance of this, stated with the estimate: 60%; the middle value does not contradict the limit.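

Going by these compounds alone, compound 4 gives > 20000 nM in this assay, a limit of the assay and not a number, so no step between compound 4 and compound 1, compound 2 or compound 3 can be read. It sits with two others at this point: the limit of > 20000 nM in this assay, at which 3 of the 4 values shown sit. Going by these compounds, how much the group on the aromatic carbon changes toxicity in this test stays open, with compound 2 the only one of the four carrying a number.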